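The compounds below may be only part of what the source reports. "The series", "measured", "known", "first", "only" and "open" are said of these compounds alone.

Compounds measured so far:
Compound 1, `COc1ccc(-c2ccc(F)c(C(=O)Nc3c[nH]nc3C(=O)Nc3ccc(F)cc3)c2F)cn1`: in a functional assay on A2058 cells (Homo sapiens) for antiproliferative activity, read by luminescence and CellTiter-Glo, with a stated time of 96 h (a higher number here means a weaker inhibitor, a lower number a stronger inhibitor), compound 1 gives "not determined" (no result reported).
Compound 2, `Nc1ccc(-c2ccc(F)c(C(=O)Nc3c[nH]nc3C(=O)Nc3ccc(F)cc3)c2F)cn1`: in this assay compound 2 gives 8540 nM.
Compound 3, `COC(=O)c1cccc(-c2ccc(F)c(C(=O)Nc3c[nH]nc3C(=O)Nc3ccc(F)cc3)c2F)c1`: in this assay compound 3 gives "not determined" (no result reported).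

The account moves from compound 3 to compound 4, `NC(=O)c1ccc(-c2ccc(F)c(C(=O)Nc3c[nH]nc3C(=O)Nc3ccc(F)cc3)c2F)cn1`. Compound 3 stands nowhere on the numbers shown: it has no single value in this assay, and compound 1 is the one further member of the set without a number, so no comparison of measured values is open to it. Among the compounds with values here, the only number in the set is the half-maximal inhibitory concentration of compound 2 in this assay, 8540 nM.

The change is 6-carbamoylpyridin-3-yl in place of 3-(methoxycarbonyl)phenyl on an aromatic carbon. Within the data shown here, with no measured pair that differs in one place, no step size has been observed. Among the measured compounds shown here, the writer therefore expects no step in this assay that can be called larger than the scatter in either direction, and he does not rule out a move beyond it.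

Compound 4 is estimated to fall near 6000 nM in this assay, with a likely range from 1200 nM to 30000 nM, the expectation resting on the weak value of compound 2, 8540 nM.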

Compound 4, half-maximal inhibitory concentration: 295 nM
Beside the measured number, compound 4's estimate is 20-fold (1.31 log units) above it; measured number outside the range, below it.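

In this assay, within the data shown here, this assay, the aromatic carbon that carries the amino group in compound 2 and the carbamoyl group in compound 4 turns out to be a place where a single change moves the number well past the scatter, with a 29-fold lower number from compound 2 to compound 4 (1.46 log units; beyond the scatter) as the first step that can be read in this set. Compound 2, at 8540 nM, had given only a weak value, whereas compound 4, at 295 nM, shows that the shared core is not tied to that weak level once this one group is exchanged. Nothing at hand gives a measured property of either group that would explain a step of this size.

Steps involving compound 1 or compound 3 cannot be read, so the methoxy group and the 3-(methoxycarbonyl)phenyl group offer no comparison with the carbamoyl group. Going by these compounds, it stays open whether the lower number is specific to the carbamoyl group or would also hold for a carboxylic acid, a nitrile or an N-methyl carboxamide on the same carbon, and whether the carbamoyl group would give it on a six-membered aromatic ring of carbon only.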